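The compounds below may be only part of what the source reports. "The series", "measured", "known", "first", "only" and "open" are said of these compounds alone.

Measured so far:
- compound 1 `COc1ccc(-c2nc(CNC(=O)c3cccnc3)sc2-c2ccc(OC)cc2)cc1`, in a functional assay with Oryctolagus cuniculus as the target (a higher number here means a weaker inhibitor, a lower number a stronger inhibitor), compound 1 gives 25 nM.
- compound 2 `COc1ccc(-c2nc(C(=O)N3CCNC(CCO)C3)sc2-c2ccc(OC)cc2)cc1`, in this assay compound 2 gives only a limit, > 1000 nM.

For the measured compounds named here, compound 1 holds the only actual number in this set; the other value is the limit, (the limit of > 1000 nM in this assay, at which 1 of the 2 values shown sits), so no measured step can be drawn between the two.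

Compound 3 `COc1ccc(-c2nc(C3=NNC(=O)CC3)sc2-c2ccc(OC)cc2)cc1` is not yet measured. It differs from compound 1 in one place (a group of 7 heavy atoms (4 carbon, 2 nitrogen, 1 oxygen; one six-membered non-aromatic ring with 2 hetero atoms) in place of a group of 10 heavy atoms (7 carbon, 2 nitrogen, 1 oxygen; one six-membered aromatic ring with 1 hetero atom), on an aromatic carbon), the new ring standing on an aromatic carbon of the shared core.

Going by the values given here, with no measured step of this size in hand, the expectation rests on compound 1 alone, which gives 25 nM. The step from compound 1 to compound 3 is expected to run toward weaker inhibition by about a 6.0-fold higher number from compound 1 to compound 3 (0.78 log units; beyond the scatter), a step beyond the usual scatter. Compound 3 is therefore estimated at 150 nM, within a range of 30 nM to 900 nM.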

Compound 3, half-maximal inhibitory concentration: > 1000 nM
Compound 3: no number, only a limit; the forecaster's own chance of this, stated with the estimate: 25%; middle value at least 6.6-fold (0.82 log units) away from the limit.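

Swapping the (((pyridin-3-yl)carbonyl)amino)methyl group on the aromatic carbon next to the ring nitrogen and the ring sulfur for the six-membered non-aromatic ring gives, in this assay, an at least 40-fold higher number from compound 1 to compound 3 (1.60 log units; beyond the scatter). The counts of hydrogen-bond donors and acceptors are the same in both groups, so matching those counts is not enough at this position to keep the value of compound 1. Compound 3 stands at a limit, so the step fixes only the smallest possible size of the change: the limit of > 1000 nM in this assay, at which 2 of the 3 values shown sit.

Since the pyridine ring, the amide and the methylene link all leave in one change, their separate contributions remain unresolved. Also open, going by these compounds, is whether an aminomethyl group, a carboxylic acid or a longer chain carrying the same pyridine amide at this carbon would hold the value of compound 1.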